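The compounds below may be only part of what the source reports. "The series", "measured", "known", "first", "only" and "open" are said of these compounds alone.

Measured so far:
compound 1 `CNC(=O)c1ccccc1Oc1nc(Nc2ccc(Br)cc2)ncc1Br` — 23500 nM
compound 2 `COc1cc(Nc2ncc(Br)c(Oc3ccc([N+](=O)[O-])cc3F)n2)cc(OC)c1OC` — 1940 nM

In a functional assay on A549 cells (Homo sapiens) for antiproliferative activity, read by MTT assay, with a stated time of 24 h (on this read-out higher numbers stand for weaker inhibition and lower numbers for stronger inhibition), compound 2 gives 1940 nM, the lower of the two numbers; the gap to compound 1 lies well beyond the scatter. Compound 3 `COc1cc(Nc2ncc(Br)c(ONCCCN)n2)cc(OC)c1OC` is not yet measured. It differs from compound 2 by (3-aminopropyl)amino in place of 2-fluoro-4-nitrophenyl on an oxygen on an aromatic ring. Among the compounds with values here, no step between measured compounds covers a change of this kind, so the expectation rests on compound 2 alone. In this assay a shift toward weaker inhibition, clearly beyond the scatter, is expected, amounting to a 5.2-fold higher number from compound 2 to compound 3 (0.71 log units; beyond the scatter). For compound 3 the expected value is 10000 nM, with a range from 2000 nM to 50000 nM.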

Compound 3, half-maximal inhibitory concentration: 13300 nM
Compound 3: middle estimate off by 1.3-fold (0.12 log units), on the low side; low and high end bracket the measured number.
By their numbers in this assay, from the lowest: compound 2; then compounds 3 and 1 (each within the scatter of the next).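

Within the data shown here, on the oxygen on the aromatic ring, (3-aminopropyl)amino in place of 2-fluoro-4-nitrophenyl weakens inhibition in this assay, with a 6.9-fold higher number from compound 2 to compound 3 (0.84 log units; beyond the scatter) as the first one-place comparison. This position therefore responds to the group it carries, and of the two groups tested, 2-fluoro-4-nitrophenyl gives the stronger inhibition. Nothing available here accounts for the shift. Going by these compounds, compound 2 and compound 3 differ in both the ring and the chain, so the contribution of each stays open. A plain phenyl or a (3-hydroxypropyl)amino group at this place would help separate them.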